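The source may report more compounds than this note shows. Statements on the series, on what has been measured and on what is new or still open speak of the compounds shown alone.

Measured compounds in the series:

compound 1, `COC(=O)c1sc2cc(-c3ccc4ccccc4c3)cnc2c1N` — in a functional assay on A-375 cells (Homo sapiens) for inhibition, read by sulforhodamine B assay, with a stated time of 48 h (on this read-out lower numbers stand for stronger inhibition of growth and higher numbers for weaker inhibition of growth), compound 1 gives 95600 nM
compound 2, `COC(=O)c1sc2cc(-c3cncc4ccccc34)cnc2c1N` — in this assay compound 2 gives 10100 nM
compound 3, `COC(=O)c1sc2cc(-c3ccc(C(C)=O)cc3)cnc2c1N` — for compound 3 this assay returns only a limit, > 150000 nM

Compound 3 therefore stands at the weak end of the numbers seen so far: its value is a limit of the assay and not a number, and it sits at the limit of > 150000 nM in this assay, at which 1 of the 3 values shown sits. Compounds 1 and 2 carry fused bicyclic aryl groups at the same position and both give numbers, whereas compound 3, with its para-substituted phenyl ring, does not.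

Compound 4, `COC(=O)c1sc2cc(-c3ccc(OC)cc3)cnc2c1N`, differs from compound 3 in one place: methoxy in place of acetyl on an aromatic carbon. Among the measured compounds shown here, no measured pair makes this exchange, so its effect here is unknown. The expectation is a step from compound 3 to compound 4 of an at least 1.5-fold lower number from compound 3 to compound 4 (0.17 log units; that floor lies within the scatter), that is, toward somewhat stronger growth inhibition, but with a fair chance that the assay again reports only a limit. Compound 4 is estimated at 100000 nM in this assay, with a range of 25000 nM to 300000 nM.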

Compound 4, concentration for 50% growth inhibition: > 150000 nM
Compound 4: a limit, no number (the forecaster's own chance of this, stated with the estimate: 45%); middle value at least 1.5-fold (0.17 log units) from the limit.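

Compound 3 and compound 4 each return only a limit of the assay, so no step for methoxy in place of acetyl can be read between them: the limit of > 150000 nM in this assay, at which 2 of the 4 values shown sit.

The compounds shown leave open how far either compound lies past that limit, and whether this exchange changes growth inhibition at all.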